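A few compounds are considered here, and "the series" means these few. Any claim that something is new, unique, unknown or untested is made for them only; others in the source may bear on it.

Compound 1 `Cc1nc(-c2ccc(C(F)(F)F)cc2)sc1CNc1ccc(CC(=O)O)cc1` and compound 2 `O=C(O)[C@@H]1C[C@H]1c1ccc(NCc2cccc(Oc3ccccc3)c2)cc1` were both tested in a functional assay on CHO cells for agonist activity at Free fatty acid receptor 1 (Homo sapiens); on this read-out lower numbers stand for an effect already at smaller amounts and higher numbers for an effect only at larger amounts of compound. For compound 1 this assay reports only a limit, < 10000 nM, and not a number. That is where compound 1 stands: at the limit of < 10000 nM in this assay, at which 1 of the 2 values shown sits. Compound 2 gives 562 nM in this assay. Within the data shown here, no two measured compounds differ in one place alone, so there is no measured step to lean on.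

Compound 3 `Cc1nc(-c2ccc(C(F)(F)F)cc2)sc1CNc1ccc([C@H]2C[C@@H]2C(N)=O)cc1` has not been measured. It differs from compound 1 by 2-carbamoylcyclopropyl in place of carboxymethyl on an aromatic carbon. The entering group shares its three-membered ring with compound 2, but compound 2 keeps an acid where compound 3 carries an amide, so that pair does not give a direct comparison either.

With compound 1 known only through a limit, the step from compound 1 to compound 3 is expected to be a step that the limit leaves unreadable from compound 1 to compound 3, with no clear direction beyond the scatter. Compound 3 is expected to give about 3000 nM in this assay, within 500 nM to 20000 nM, and a further limit rather than a number is a real possibility.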

Compound 3, half-maximal effective concentration: 4.47 nM
For compound 3 the middle estimate is 670-fold (2.83 log units) above the measured one; measured number outside the range, below it.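

No size can be read for the change from compound 1 to compound 3, because this assay gives only a limit for compound 1: the limit of < 10000 nM in this assay, at which 1 of the 3 values shown sits.

The compounds shown leave open how much 2-carbamoylcyclopropyl in place of carboxymethyl changes the value on the shared core, and how the amide of compound 3 compares with an acid on the same three-membered ring.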